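The source may report more compounds than this note shows. Statements on the series, on what has been measured and on what is new or still open speak of the compounds shown alone.

In a functional assay on MCF7 cells (Homo sapiens) for antiproliferative activity, read by MTT assay, with a stated time of 24 h (on this read-out lower numbers stand for stronger inhibition and higher numbers for weaker inhibition), compound 1 `CCn1c(C(=O)N[C@@H](CO)C(C)C)ccc1C(CC)(CC)c1ccc(OCS(=O)(=O)c2ccccc2)c(C)c1` gives 18800 nM and compound 2 `CCn1c(C(=O)N[C@@H](C)C(=O)O)ccc1C(CC)(CC)c1ccc(OCS(=O)(=O)c2ccccc2)c(C)c1` gives 35500 nM. Compound 3 `CCn1c(C(=O)N[C@H](C)C(=O)O)ccc1C(CC)(CC)c1ccc(OCS(=O)(=O)c2ccccc2)c(C)c1` reaches only a limit of the assay, > 50000 nM. Compound 4 `CCn1c(C(=O)N[C@H](CCC(=O)O)C(=O)O)ccc1C(CC)(CC)c1ccc(OCS(=O)(=O)c2ccccc2)c(C)c1` differs from it by carboxymethyl in place of hydrogen on a saturated chain carbon, two bonds along the chain from an amide-type nitrogen and a carbonyl carbon, which turns 1-carboxyethyl into 1,3-dicarboxypropyl. Within the data shown here, no measured step makes this exact change. The nearest evidence is the swap to 1-carboxyethyl, with a 1.9-fold higher number from compound 1 to compound 2 (0.28 log units; within the scatter) and an at least 2.6-fold higher number from compound 1 to compound 3 (0.42 log units; beyond the scatter), plus the change of configuration alone, with an at least 1.4-fold higher number from compound 2 to compound 3 (0.14 log units; that floor lies within the scatter). None of these steps hints at stronger inhibition, so the expected step is a number no higher from compound 3 to compound 4 (the limit leaves the size open), with no change expected beyond the scatter. Compound 4 is estimated at 50000 nM, within an expected range of 20000 nM to 120000 nM.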

Compound 4, half-maximal inhibitory concentration: > 50000 nM
Compound 4: a limit, no number (the forecaster's own chance of this, stated with the estimate: 65%); the middle value sits exactly at the limit.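

Carboxymethyl on this saturated chain carbon does not bring compound 4 back from the limit in this assay, where compound 3 also stands, so the step between those two cannot be read. The steps that can be read are an at least 1.4-fold higher number from compound 2 to compound 4 (0.14 log units; that floor lies within the scatter) and an at least 2.6-fold higher number from compound 1 to compound 4 (0.42 log units; beyond the scatter). A second carboxylic acid, as in 1,3-dicarboxypropyl, thus gives no readable gain in inhibition, and the assay can show nothing further here: the limit of > 50000 nM in this assay, at which 2 of the 4 values shown sit.

From the compounds shown here alone, whether an amine or a longer chain on this carbon would give a number under the limit stays open. So does how far compound 3 and compound 4 really lie past it.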